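Cytotoxicity notes on the next benzyl variant, compound 3

The compounds below may be only part of what the source reports. "The series", "measured", "known", "first", "only" and "open" are said of these compounds alone.

Measured so far:
- compound 1 `Cn1cc(SCc2nnc(SCc3ccccc3OC(F)(F)F)n2-c2c(Cl)cccc2Cl)c2ccccc21`: in a toxicity assay on HEK-293T cells (Homo sapiens) for cytotoxicity, read by CCK-8 assay, with a stated time of 48 h (a lower number here means that less compound is tolerated, a higher number that more compound is tolerated), compound 1 gives only a limit, > 100000 nM.
- compound 2 `Cn1cc(SCc2nnc(SCc3cccc(Cl)c3F)n2-c2c(Cl)cccc2Cl)c2ccccc21`: in this assay compound 2 likewise gives only a limit, > 100000 nM.

Compound 1 therefore stands at the edge of what this assay can read, with no number of its own; the same holds for compound 2, so both values sit at the limit of > 100000 nM in this assay, at which 2 of the 2 values shown sit. Among the measured compounds shown here, the one measured step, a step that the two limits leave unreadable from compound 1 to compound 2, is unreadable for that reason.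

Compound 3 `Cn1cc(SCc2nnc(SCc3ccc(Cl)cc3F)n2-c2c(Cl)cccc2Cl)c2ccccc21` differs from compound 1 by 4-chloro-2-fluorophenyl in place of 2-(trifluoromethoxy)phenyl on a saturated chain carbon bound to a sulfur. For the measured compounds named here, the only step that bears on this change is the unreadable one from compound 1 to compound 2, which swapped the same group for a closely related chlorofluorophenyl; it gives no size and no direction. The expected step in this assay is a step that the limit leaves unreadable from compound 1 to compound 3, meaning none beyond the scatter and most likely another limit. For compound 3 the estimate is 150000 nM, ranging from 50000 nM to 400000 nM.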

Compound 3, half-maximal cytotoxic concentration: 87300 nM
Beside the measured number, compound 3's estimate is 1.7-fold (0.24 log units) above it; low and high end bracket the measured number.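

Among the compounds shown here, with 4-chloro-2-fluorophenyl on the saturated chain carbon bound to a sulfur, compound 3 gives the first readable number of the series in this assay, 87300 nM. The steps read an at least 1.1-fold lower number from compound 1 to compound 3 (0.05 log units; that floor lies within the scatter) and an at least 1.1-fold lower number from compound 2 to compound 3 (0.05 log units; that floor lies within the scatter); both are only floors, so no lowering beyond the scatter is established, while larger true gaps are not excluded. Compound 1 and compound 2 remain limits, not numbers: the limit of > 100000 nM in this assay, at which 2 of the 3 values shown sit.

Going by these compounds, how far compound 1 and compound 2 truly lie from compound 3 stays open, so 2-(trifluoromethoxy)phenyl, 3-chloro-2-fluorophenyl and 4-chloro-2-fluorophenyl cannot be ranked. Also open, on these data alone, is how an amine or a carboxylic acid in place of the 4-chloro-2-fluorophenyl would read in this assay.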